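Swapping Benzyl for Methoxyphenyl on a Sulfonamide Nitrogen

The compounds below may be only part of what the source reports. "The series", "measured", "known", "first", "only" and "open" are said of these compounds alone.

Compound 1, `CC1(C)C=C(n2ccccc2=O)c2cc(S(N)(=O)=O)ccc2O1`: 92.1%
Compound 2, `CNS(=O)(=O)c1ccc2c(c1)C(n1ccccc1=O)=CC(C)(C)O2`: 83%
Compound 3, `CC1(C)C=C(n2ccccc2=O)c2cc(S(=O)(=O)NCc3ccccc3)ccc2O1`: 77.5%

In a functional assay on the whole organism (trachea) with Rattus norvegicus as the target (on this read-out higher numbers stand for larger maximal responses and lower numbers for smaller maximal responses), compound 3 shows the lowest of the three numbers; its gap to compound 2 lies within the scatter, whereas a number 14.6 percentage points lower from compound 1 to compound 3 (beyond the scatter) lies beyond it. Compound 4, `COc1ccc(NS(=O)(=O)c2ccc3c(c2)C(n2ccccc2=O)=CC(C)(C)O3)cc1`, differs from compound 3 by 4-methoxyphenyl in place of benzyl on a sulfonamide nitrogen. Within the data shown here, no measured step replaces one group by another on this nitrogen, so the steps that bear on it are a number 14.6 percentage points lower from compound 1 to compound 3 (beyond the scatter), a modest drop, and a number 5.5 percentage points lower from compound 2 to compound 3 (within the scatter), within the scatter. Substitution at this nitrogen has so far left the maximal response unchanged within the scatter or lowered it modestly, so a further small decrease is expected, a number 5.5 percentage points lower from compound 3 to compound 4 (within the scatter), possibly within the scatter. Compound 4 is estimated at 72%, between 56% and 88%.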

Compound 4, largest response reached (Emax), in percent of the reference or control that the assay uses: 84.2%
Compound 4: the middle estimate sits 12.2 percentage points below what was measured, and the stated range covers the measured number.
By their numbers in this assay, from the lowest: compounds 3, 2, 4 and 1 (each within the scatter of the next, the first and the last beyond it).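

Among these compounds, this is the first direct exchange of one group for another on the sulfonamide nitrogen, and in this assay 4-methoxyphenyl in place of benzyl gives a number 6.7 percentage points higher from compound 3 to compound 4 (within the scatter). Against the smaller groups, the same substituent gives a number 1.2 percentage points higher from compound 2 to compound 4 (within the scatter) and a number 7.9 percentage points lower from compound 1 to compound 4 (within the scatter), so unlike benzyl, it stays within the scatter of the unsubstituted sulfonamide. No supporting measurement accounts for this difference. Still open, going by these compounds, is whether the methoxy group matters, or whether a plain phenyl would read the same. On these data alone, a carboxylic acid or an amine on that ring also remains untested here.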